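The source may hold more compounds than are shown below. What is called first, only, known or untested is meant among the compounds shown, and "the series" means these compounds.

Compound 3 `Cc1ccc2oc(=O)c(/C=N/c3ccc(S(N)(=O)=O)cc3)c(Cl)c2c1` gives 360 nM in a functional assay on B16-F10 cells (Mus musculus) for cytotoxicity, read by CCK-8 assay, with a stated time of 48 h (on this read-out higher numbers stand for weaker inhibition and lower numbers for stronger inhibition), the highest of the three numbers recorded, though each gap to the others sits inside the usual scatter. Within the data shown here, compound 1 `NS(=O)(=O)c1ccc(/N=C/c2c(Cl)c3ccccc3oc2=O)cc1` gives 300 nM in this assay, and the only single-point step so far, a 1.2-fold higher number from compound 1 to compound 3 (0.08 log units; within the scatter), is the methyl on an aromatic carbon. Compound 2 `Cc1cc(C)nc(NS(=O)(=O)c2ccc(/N=C/c3c(Cl)c4cc(C(C)(C)C)cc(C(C)(C)C)c4oc3=O)cc2)n1` gives 220 nM in this assay; it differs from compound 1 in more than one place, so its reading shows only that a substituted sulfonamide nitrogen is compatible with a similar number. Compound 4 `Cc1ccc2oc(=O)c(/C=N/c3ccc(S(=O)(=O)Nc4cc(C)on4)cc3)c(Cl)c2c1` carries 5-methyl-1,2-oxazol-3-yl in place of hydrogen on a sulfonamide nitrogen. Among the measured compounds shown here, no measured step isolates this change. Given that compound 2 gives 220 nM with a substituted sulfonamide nitrogen, compound 4 is expected to show a 1.2-fold lower number from compound 3 to compound 4 (0.08 log units; within the scatter), nothing beyond the scatter. Compound 4 is therefore estimated at 300 nM, between 140 nM and 650 nM.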

Compound 4, half-maximal inhibitory concentration: 250 nM
The estimate for compound 4 lay 1.2-fold (0.08 log units) above the measured number; measured number inside the range.
By their numbers in this assay, from the lowest: compounds 2, 4, 1 and 3 (each within the scatter of the next).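

On the core of compound 3, 5-methyl-1,2-oxazol-3-yl replaces hydrogen on the sulfonamide nitrogen with a 1.4-fold lower number from compound 3 to compound 4 (0.16 log units; within the scatter) in this assay. Among these compounds, this is the first single-place reading at this position, and it shows that the sulfonamide hydrogen can be replaced by this aromatic ring without a step beyond the scatter. No measurement available here offers an explanation for this reading.

As far as these compounds go, it remains open whether an acetyl group or a longer alkyl chain on this nitrogen would also stay within the scatter. The compounds shown also do not separate the contribution of the ring's methyl from that of the ring itself.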